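Extending the Ester from Benzyl to Phenethyl

This account rests on a few compounds, and the source may have more. Where it says the series, first, only, none or still open, it means among the compounds named here.

Compound 1 `CCOC(=O)C1=C(C)NC(C)=C(C(=O)OCC)C1c1csc(-c2ccc(Cl)cc2)n1` and compound 2 `CCOC(=O)C1=C(C)NC(C)=C(C(=O)OCc2ccccc2)C1c1csc(-c2ccc(Cl)cc2)n1` share one core and differ only in the ester group. In an assay on isolated protein for antagonist activity at Voltage-dependent L-type calcium channel subunit alpha-1C (Cavia porcellus), with a stated time of 15 min (a lower number here means a stronger inhibitor, a higher number a weaker inhibitor), compound 1 gives 3650 nM, and compound 2 gives 3290 nM. The step of a 1.1-fold lower number from compound 1 to compound 2 (0.05 log units; within the scatter) left the number essentially unchanged, so compound 2 stands alongside compound 1, the two numbers lying within the scatter. Compound 3 `CCOC(=O)C1=C(C)NC(C)=C(C(=O)OCCc2ccccc2)C1c1csc(-c2ccc(Cl)cc2)n1` carries the change (benzyl in place of phenyl on a saturated chain carbon bound to an oxygen next to a carbonyl group). Within the data shown here, only this single measured step bears on it, and it was small, so no shift beyond the scatter is expected in this assay for compound 3. The expected step is a 1.1-fold lower number from compound 2 to compound 3 (0.04 log units; within the scatter). Compound 3 is therefore estimated at 3000 nM, between 1200 nM and 7500 nM.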

Compound 3, half-maximal inhibitory concentration: 12100 nM
Beside the measured number, compound 3's estimate is 4.0-fold (0.61 log units) below it; measured number outside the range, above it.
By their numbers in this assay, from the lowest: compounds 2 and 1 (each within the scatter of the next); then compound 3.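

In this assay, the ester position proved sensitive to the length of the chain carrying the phenyl ring, which the earlier pair had not revealed: benzyl to phenethyl gave a 3.7-fold higher number from compound 2 to compound 3 (0.57 log units; beyond the scatter), and the ethyl ester to phenethyl gave a 3.3-fold higher number from compound 1 to compound 3 (0.52 log units; beyond the scatter). The tolerance seen for the benzyl ester therefore did not extend to phenethyl. Nothing available explains this rise. As far as these compounds go, whether a longer chain such as phenylpropyl would raise the number further remains open, as does the effect of an amine at the end of the ester chain.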